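The source may hold more compounds than are shown below. What is called first, only, known or untested is meant among the compounds shown, and "the series" means these compounds.

Measured in a functional assay on KB cells (Homo sapiens) for antiproliferative activity, read by sulforhodamine B assay, with a stated time of 3 days; on this read-out lower numbers stand for an effect already at smaller amounts and higher numbers for an effect only at larger amounts of compound:
Compound 1 `CCC1=C(O)c2c(oc(-c3ccc(C(C)C)cc3)cc2=O)C(CC)(CC)C1=O`: 8.13 uM
Compound 2 `CCC1=C(O)c2c(oc(-c3ccc(COC)cc3)cc2=O)C(CC)(CC)C1=O`: > 52.4 uM, a limit of the assay
Compound 3 `CCC1=C(O)c2c(oc(-c3cccc(C)c3)cc2=O)C(CC)(CC)C1=O`: 49.7 uM

Compound 3 holds the higher of the two actual numbers, the measured step being a 6.1-fold higher number from compound 1 to compound 3 (0.79 log units; beyond the scatter). Compound 4 `CCC1=C(O)c2c(oc(-c3ccc(C)c(C)c3)cc2=O)C(CC)(CC)C1=O` differs from it by methyl in place of hydrogen on an aromatic carbon, turning 3-methylphenyl into 3,4-dimethylphenyl. Compound 1, with its 4-isopropylphenyl, points towards a lower number through that step. Compound 2, with its 4-(methoxymethyl)phenyl, goes against this, at an at least 6.4-fold higher number from compound 1 to compound 2 (0.80 log units; beyond the scatter). A lower number is therefore expected in this assay, though by less than the step to compound 1 would suggest. The estimated change is a 1.9-fold lower number from compound 3 to compound 4 (0.28 log units; within the scatter). Compound 4 is expected at 26 uM, with an estimated range of 11 uM to 55 uM.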

Compound 4, concentration for half-maximal effect: 35.5 uM
Beside the measured number, compound 4's estimate is 1.4-fold (0.14 log units) below it; the measured number falls inside the stated range.
By their numbers in this assay, from the lowest: compound 1; then compounds 4 and 3 (each within the scatter of the next). At a limit, above all of these: compound 2.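

In this assay, methyl in place of hydrogen on the aromatic carbon ortho to a methyl group and para to a large group gives a 1.4-fold lower number from compound 3 to compound 4 (0.15 log units; within the scatter) and so leaves 3-methylphenyl and 3,4-dimethylphenyl within the scatter of each other. The 4-isopropylphenyl of compound 1 remains apart, with a 4.4-fold higher number from compound 1 to compound 4 (0.64 log units; beyond the scatter), so a methyl on this carbon does not match that group. 3,4-Dimethylphenyl in place of 4-(methoxymethyl)phenyl gives an at least 1.4-fold lower number from compound 2 to compound 4 (0.16 log units; that floor lies within the scatter) and so sets no order between the two. Compound 2 stands at a limit of the assay: the limit of > 52.4 uM in this assay, at which 1 of the 4 values shown sits.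

The compounds shown leave open how an ethyl group, a tert-butyl group or an amine on this carbon would read in this assay. They also leave open whether the methyl of 3-methylphenyl alters the reading of a larger group there.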